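The compounds below may be only part of what the source reports. "The series", "measured", "known", "first", "only" and "open" are said of these compounds alone.

Compound 1 `COc1ccc(C(=O)c2cc(/C=C/C(=O)NO)n(C)c2)cc1` — 75.2%
Compound 2 `Cn1cc(C(=O)c2ccccc2)cc1/C=C/C(=O)NCCO` — 0.9%

Both compounds were tested in an assay on isolated protein for inhibition of histone deacetylase HD2 (Zea mays), tested at 30 uM; a lower number here means less inhibition, a higher number more inhibition at the concentration tested (going by the name of the read-out). Compound 1 stands highest of the two numbers; compound 2 gives a value far lower, a gap beyond the usual scatter of this assay. Compound 3 `Cn1cc(C(=O)c2ccc(F)cc2)cc1/C=C/C(=O)NO` has not yet been measured. It differs from compound 1 in one place: fluoro in place of methoxy on an aromatic carbon. For the measured compounds named here, no measured pair shows what this exchange does, so the expected step in this assay is small, in either direction, probably within the scatter. Compound 3 is therefore estimated at 70%, with a range from 50% to 85%, an expected step of a number 5.2 percentage points lower from compound 1 to compound 3 (within the scatter).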

Compound 3, a percentage reported as inhibition, at one concentration (the size of the read-out at that concentration, not a potency): 84%
The estimate for compound 3 lay 14 percentage points below the measured number; low and high end bracket the measured number.
By their numbers in this assay, from the lowest: compound 2; then compounds 1 and 3 (each within the scatter of the next).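

On an aromatic carbon of the six-membered ring, para to a large group, fluoro can replace methoxy without a clear change in this assay: the step is a number 8.8 percentage points higher from compound 1 to compound 3 (within the scatter). At this position, then, inhibition at the tested concentration does not depend on keeping the methoxy group, and a single fluorine atom serves as well. No supporting data bear on this result.

Going by these compounds, it remains open whether an amine, a carboxylic acid or a longer alkoxy chain would be accepted here. A reading at one concentration also leaves the potency of compound 1 and compound 3 open.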